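The source may report more compounds than this note shows. Statements on the series, on what has been measured and on what is new or still open speak of the compounds shown alone.

Measured in a functional assay on PC-3 cells (Homo sapiens) for cytotoxicity, read by MTT assay, with a stated time of 48 h; a higher number here means a weaker inhibitor, a lower number a stronger inhibitor:
compound 1 `CCNCC(=O)N1N=C(c2cc3ccccc3oc2=O)CC1c1ccccc1`: 5580 nM
compound 2 `CC(C)(C)NCC(=O)N1N=C(c2cc3ccccc3oc2=O)CC1c1ccccc1`: 16400 nM

Going by the values given here, compound 2 gives the highest of these two numbers in this assay; the only measured step, a 2.9-fold higher number from compound 1 to compound 2 (0.47 log units; beyond the scatter), lies beyond the scatter and is modest in size. Compound 3 `CC1CCCCN1CC(=O)N1N=C(c2cc3ccccc3oc2=O)CC1c1ccccc1` has not yet been measured. It differs from compound 2 in one place: 2-methylpiperidin-1-yl in place of (tert-butyl)amino on a saturated chain carbon bound to a carbonyl carbon. Among the compounds with values here, no measured pair shows this exchange of a group with no ring for a six-membered non-aromatic ring, so the only step that bears on it is the one in which an ethyl on the amine nitrogen became a tert-butyl, a modest weakening. That gives weak guidance only, so the step of a 1.6-fold lower number from compound 2 to compound 3 (0.21 log units; within the scatter) in this assay is expected to be small, with its direction uncertain. Compound 3 is therefore estimated at 10000 nM, with a range from 3500 nM to 30000 nM.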

Compound 3, half-maximal inhibitory concentration: 36300 nM
Beside the measured number, compound 3's estimate is 3.6-fold (0.56 log units) below it; measured number outside the range, above it.
By their numbers in this assay, from the lowest: compound 1; then compound 2; then compound 3.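

Swapping (tert-butyl)amino for 2-methylpiperidin-1-yl on this saturated chain carbon bound to a carbonyl carbon gives a 2.2-fold higher number from compound 2 to compound 3 (0.35 log units; beyond the scatter) in this assay, so a six-membered non-aromatic ring at this place does not win back what was lost with the tert-butyl group. Set against the ethylamino group, the same ring gives a 6.5-fold higher number from compound 1 to compound 3 (0.81 log units; beyond the scatter) in this assay, which leaves ethylamino as the best of the three groups shown here. No measurement shown accounts for this loss.

The new group differs from (tert-butyl)amino both in having a ring and in lacking a hydrogen-bond donor, and these compounds cannot separate the two changes. Piperidin-1-yl without the methyl, morpholin-4-yl or open-chain diethylamino could help tell them apart.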